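Solubility notes: benzyl substituent change on the shared core

A few compounds are considered here, and "the series" means these few. Any claim that something is new, unique, unknown or untested is made for them only; others in the source may bear on it.

compound 1 `Cc1noc(-c2nc(C)c3c(c2N)C(=O)N(Cc2ccc(-c4ccncc4)cc2)C3=O)n1`: < 5000 nM
compound 2 `Cc1noc(-c2nc(C)c3c(c2N)C(=O)N(Cc2cccc(F)c2)C3=O)n1`: < 5000 nM

In a physicochemical assay for solubility, using the shake flask method, in simulated intestinal fluid, measured as kinetic solubility, with a stated time of 2 h, at 25 degrees C, at pH 6.5 (a lower number here means a less soluble compound, a higher number a more soluble compound), compound 1 gives < 5000 nM, which is a limit of the assay and not a number. In this assay compound 2 gives < 5000 nM, likewise a limit. Compound 2 therefore stands at the limit of < 5000 nM in this assay, at which 2 of the 2 values shown sit, so no numbered comparison among measured compounds is available. Compound 3 `Cc1noc(-c2nc(C)c3c(c2N)C(=O)N(Cc2ccc(S(C)(=O)=O)cc2)C3=O)n1` has not been measured in this assay; it differs from compound 2 by 4-(methylsulfonyl)phenyl in place of 3-fluorophenyl on a saturated chain carbon bound to an amide-type nitrogen in a ring. Within the data shown here, no step between measured compounds is known here. For compound 3 a rise beyond the scatter is expected, as the estimated step of an at least 1.8-fold higher number from compound 2 to compound 3 (0.25 log units; that floor lies within the scatter). Compound 3 is estimated at 9000 nM, in the range 2500 nM to 40000 nM.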

Compound 3, solubility: < 5000 nM
Compound 3: no number, only a limit; the forecaster's own chance of this, stated with the estimate: 30%; middle value at least 1.8-fold (0.25 log units) away from the limit.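

No step can be read from compound 1 or compound 2 to compound 3, because all three values are limits and not numbers: the limit of < 5000 nM in this assay, at which 3 of the 3 values shown sit.

In this assay the compounds shown leave open whether changing the benzyl substituent on the shared core alters solubility at all.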